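Aryl sulfonamide variation at the sulfonamide nitrogen

The source may report more compounds than this note shows. Statements on the series, on what has been measured and on what is new or still open speak of the compounds shown alone.

Values are from a functional assay on M21 cells (Homo sapiens) for antiproliferative activity, read by sulforhodamine B assay, with a stated time of 48 h; a lower number here means a stronger inhibitor, a higher number a weaker inhibitor.
Compound 1 `COc1ccc(NS(=O)(=O)c2ccc(N3CCNC3=O)cc2)cc1`: 580 nM
Compound 2 `O=C1NCCN1c1ccc(S(=O)(=O)Nc2ccc(F)c(F)c2)cc1`: 220 nM
Compound 3 `CC(C)Cc1ccc(NS(=O)(=O)c2ccc(N3CCNC3=O)cc2)cc1`: > 1000 nM, which is a limit of this assay rather than a number.

Compound 2 holds the lowest of the two numbers shown in this assay; the nearest number is that of compound 1, and the step between them is a 2.6-fold lower number from compound 1 to compound 2 (0.42 log units; beyond the scatter). Compound 3 sits at the floor of what this assay reports (the limit of > 1000 nM in this assay, at which 1 of the 3 values shown sits).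

Compound 4 `COc1cccc(NS(=O)(=O)c2ccc(N3CCNC3=O)cc2)c1` has not been measured in this assay. It differs from compound 2 in one place: 3-methoxyphenyl in place of 3,4-difluorophenyl on a sulfonamide nitrogen.

Within the data shown here, only one measured step bears directly on this change, the one from a methoxyphenyl to the difluorophenyl, a 2.6-fold lower number from compound 1 to compound 2 (0.42 log units; beyond the scatter), which was modest. Compound 4 runs that exchange back toward a methoxyphenyl, now the 3-methoxyphenyl, so a step of similar size in the other direction is expected. The step of an at least 1.7-fold higher number from compound 1 to compound 3 (0.23 log units; that floor lies within the scatter) shows that a bulkier isobutyl on that ring pushes the number up to the limit, but the methoxy is kept here. For compound 4 the expected step is a 2.3-fold higher number from compound 2 to compound 4 (0.36 log units; beyond the scatter), a modest rise. Compound 4 is therefore estimated at 500 nM, with a range of 200 nM to 1300 nM.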

Compound 4, half-maximal inhibitory concentration: 65 nM
Estimate against measurement, compound 4: 7.7-fold (0.89 log units) above, and the stated range ends above it.
By their numbers in this assay, from the lowest: compound 4; then compound 2; then compound 1. At a limit, above all of these: compound 3.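

In this assay, the aryl group on the sulfonamide nitrogen responds to where the methoxy stands and not only to whether a methoxy is present: with 3-methoxyphenyl in place of 4-methoxyphenyl the series shows an 8.9-fold lower number from compound 1 to compound 4 (0.95 log units; beyond the scatter) and the compound moves to the lowest number of the set. The earlier comparison favoured 3,4-difluorophenyl over 4-methoxyphenyl, but that order does not extend to methoxyphenyl groups in general, since 3-methoxyphenyl in place of 3,4-difluorophenyl gives a 3.4-fold lower number from compound 2 to compound 4 (0.53 log units; beyond the scatter) even though the exchange keeps the same count of heavy atoms. No measurement among these compounds accounts for the difference between the two methoxyphenyl groups.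

Going by these compounds, it remains open whether an ethoxy, a hydroxyl or an amine in place of the methoxy of compound 4 would hold a number of this order, or whether the methoxy itself is what matters at that place on the ring. Also open, on these data alone, is whether this order of aryl groups survives a change elsewhere in the shared core, and whether it carries over to cell lines other than the one used here.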